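The source may report more compounds than this note shows. Statements on the series, on what has been measured and on what is new or still open speak of the compounds shown alone.

Compound 1 `C/C=C(\NC(C)=O)C(=O)N1CCC[C@H]1C(=O)NN(CC(N)=O)C(=O)/C=C/C(=O)OCC` gives 141 nM in an assay on isolated protein for inhibition of legumain (Mus musculus), read by fluorescence, with stated times of 30 s and 2.5 h; a higher number here means a weaker inhibitor, a lower number a stronger inhibitor. Compound 2 `CCOC(=O)/C=C/C(=O)N(CC(N)=O)NC(=O)[C@@H]1CCCN1C(=O)C(NC(C)=O)=C(C)C` gives 148 nM in this assay.

On these two numbers compound 2 stands beside compound 1: the step of a 1.0-fold higher number from compound 1 to compound 2 (0.02 log units; within the scatter) lies within the scatter. Compound 3 `CCOC(=O)/C=C/C(=O)N(CC(N)=O)NC(=O)[C@@H]1CCCN1C(=O)c1ccc(CNC(C)=O)cc1` differs from compound 2 by a group of 11 heavy atoms (9 carbon, 1 nitrogen, 1 oxygen; one six-membered aromatic ring of carbon only) in place of a group of 8 heavy atoms (6 carbon, 1 nitrogen, 1 oxygen; no ring), on a carbonyl carbon. Going by the values given here, the only measured step at that carbonyl carbon, a 1.0-fold higher number from compound 1 to compound 2 (0.02 log units; within the scatter), changed nothing beyond the scatter, but it exchanged two groups without a ring; no measured step introduces an aromatic ring. In this assay compound 3 is therefore expected to shift by a 1.7-fold higher number from compound 2 to compound 3 (0.23 log units; within the scatter), a modest weakening that stays uncertain. The estimate for compound 3 is 250 nM, with a range from 60 nM to 1200 nM.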

Compound 3, half-maximal inhibitory concentration: 267 nM
Compound 3: middle estimate off by 1.1-fold (0.03 log units), on the low side, and the stated range covers the measured number.
By their numbers in this assay, from the lowest: compounds 1, 2 and 3 (each within the scatter of the next).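

On the carbonyl carbon whose other neighbour is the amide-type nitrogen in a ring, compound 3 brings the first aromatic ring, and in this assay the 4-(acetamidomethyl)phenyl group gives a 1.8-fold higher number from compound 2 to compound 3 (0.26 log units; within the scatter) and a 1.9-fold higher number from compound 1 to compound 3 (0.28 log units; within the scatter). Both steps lie within the scatter, so at this position a group with a six-membered aromatic ring of carbon only reads level with the two groups without a ring.

From the compounds shown here alone, how an aminomethyl group or a carboxylic acid in place of the acetamidomethyl group on the phenyl would read in this assay stays open. Nothing available explains why this exchange leaves the reading level.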